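This account rests on a few compounds, and the source may have more. Where it says the series, first, only, none or still open, it means among the compounds named here.

In a functional assay on brain (Rattus norvegicus, strain Wistar) for inhibition (on this read-out higher numbers stand for weaker inhibition and lower numbers for stronger inhibition), compound 1 `CCCCc1ccc(-c2c(C)[nH]c(=O)n2C)cc1` gives 10700 nM and compound 2 `CCCCc1ccc(-c2c(C)[nH]c(=O)n2C(C)C)cc1` gives 10700 nM. Compound 3 `CCCCn1c(-c2ccccc2)c(C)[nH]c1=O` is known only as a limit, > 100000 nM. Compound 4 `CCCCc1ccc(-c2c(C)[nH]c(=O)n2CCCC)cc1` departs from compound 3 by butyl in place of hydrogen on an aromatic carbon, para to a large group. Among the compounds with values here, the one measured step that bears on this is no change at the digits printed from compound 1 to compound 2 (within the scatter), isopropyl in place of methyl on an aromatic nitrogen. Compound 4 shares this butyl with compound 2, so a value near the 10700 nM of compound 2 is expected. The expected change is a large one toward stronger inhibition, an at least 11-fold lower number from compound 3 to compound 4 (1.04 log units; beyond the scatter). For compound 4 the estimate is 9000 nM, with an expected range of 3000 nM to 30000 nM.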

Compound 4, half-maximal inhibitory concentration: 12000 nM
For compound 4 the middle estimate is 1.3-fold (0.12 log units) below the measured one; measured number inside the range.
By their numbers in this assay, from the lowest: compounds 1, 2 and 4 (each within the scatter of the next). At a limit, above all of these: compound 3.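

In this assay, butyl on the aromatic carbon, para to a large group, is the first change shown to matter: an at least 8.3-fold lower number from compound 3 to compound 4 (0.92 log units; beyond the scatter). From the compounds shown here alone, compound 3 is only a limit, > 100000 nM, so the full size of this step stays unknown: the limit of > 100000 nM in this assay, at which 1 of the 4 values shown sits. On the aromatic nitrogen, butyl stays within the scatter of isopropyl, a 1.1-fold higher number from compound 2 to compound 4 (0.05 log units; within the scatter), and of methyl, a 1.1-fold higher number from compound 1 to compound 4 (0.05 log units; within the scatter).

Open, going by these compounds, is whether a propyl or hexyl chain, an amine or a carboxylic acid in place of that butyl on the aromatic carbon would give a similar number. Also open, on these data alone, is whether a chain longer than butyl on the aromatic nitrogen would stay within the scatter.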